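This account rests on a few compounds, and the source may have more. Where it says the series, first, only, none or still open, it means among the compounds named here.

Working notes on the series in a functional assay on HeLa cells (Homo sapiens) for cytotoxicity, read by WST assay, with a stated time of 48 h; a higher number here means a weaker inhibitor, a lower number a stronger inhibitor. Compound 1 (`O=[N+]([O-])c1cccc(/C=C/C[C@H]2C[C@@H]([C@@H](O)c3ccccc3)CO[C@@H]2c2ccccc2)c1`) gives 7850 nM, and compound 2 (`O[C@@H](c1ccccc1)[C@H]1CO[C@H](c2ccccc2)[C@@H](C/C=C/C2CCCC2)C1`) gives 9330 nM. Compound 3 (`Cc1ccc(/C=C/C[C@H]2C[C@@H]([C@@H](O)c3ccccc3)CO[C@@H]2c2ccccc2)cc1C`) gives 10000 nM, which lies within the scatter of both other values.

Compound 4 (`O[C@@H](c1ccccc1)[C@H]1CO[C@H](c2ccccc2)[C@@H](C/C=C/c2ccncc2)C1`) has pyridin-4-yl in place of 3,4-dimethylphenyl on a double-bonded chain carbon bound to a double-bonded chain carbon.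

Three measured exchanges at this same place bear on the change: a 1.2-fold higher number from compound 1 to compound 2 (0.08 log units; within the scatter), a 1.3-fold higher number from compound 1 to compound 3 (0.11 log units; within the scatter) and a 1.1-fold higher number from compound 2 to compound 3 (0.03 log units; within the scatter). All three lie within the scatter, across 3-nitrophenyl, cyclopentyl and 3,4-dimethylphenyl. Going by the values given here, no measured compound carries a ring with a hetero atom at this place, so the new ring remains untested and the range is kept wide.

No step beyond the scatter is therefore expected in this assay, and no direction is favoured. The expected step is no change at the digits printed from compound 3 to compound 4 (within the scatter). The estimate for compound 4 is 10000 nM, with an expected range from 5500 nM to 20000 nM.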

Compound 4, half-maximal inhibitory concentration: > 100000 nM
Compound 4 gave a limit, no number (the forecaster's own chance of this, stated with the estimate: 25%); middle value at least 10-fold (1.00 log units) from the limit.
By their numbers in this assay, from the lowest: compounds 1, 2 and 3 (each within the scatter of the next). At a limit, above all of these: compound 4.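

In this assay, going by these compounds alone, this place on the chain is not as tolerant as the earlier compounds suggested: 3-nitrophenyl, cyclopentyl and 3,4-dimethylphenyl stayed within the scatter of one another, but pyridin-4-yl stands apart from all three, with an at least 10-fold higher number from compound 3 to compound 4 (1.00 log units; beyond the scatter), an at least 10-fold higher number from compound 2 to compound 4 (1.03 log units; beyond the scatter) and an at least 12-fold higher number from compound 1 to compound 4 (1.10 log units; beyond the scatter). Within the data shown here, of the four groups, pyridin-4-yl is the only ring with a hetero atom, so the first step beyond the scatter at this place comes with that ring. The value of compound 4 is a limit and not a number, so the true size of these steps stays unknown: the limit of > 100000 nM in this assay, at which 1 of the 4 values shown sits.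

The compounds shown do not tell whether the ring nitrogen alone goes with this step or whether its location in the ring also counts. Pyridin-3-yl or unsubstituted phenyl at this place would bear on that question.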